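Solubility notes: succinimide, triazole and carbamate side chains

The source may hold more compounds than are shown below. What is called first, only, known or untested is meant among the compounds shown, and "the series" means these compounds.

Measured so far:
compound 1 `O=C1CCC(=O)N1C[C@H]1CN(c2ccc(-n3cc(-c4ccccn4)cn3)c(F)c2)C(=O)O1` gives 45300 nM
compound 2 `O=C1O[C@@H](Cn2ccnn2)CN1c1ccc(-n2cc(-c3ccccn3)cn2)c(F)c1` gives 247000 nM

In a physicochemical assay for solubility, read by HPLC, with a stated time of 24 h (on this read-out lower numbers stand for lower solubility and higher numbers for higher solubility), compound 1 holds the lowest of the two numbers. For the measured compounds named here, the only measured step is a 5.5-fold higher number from compound 1 to compound 2 (0.74 log units; beyond the scatter), which replaces the five-membered imide with an aromatic azole on the same saturated chain carbon bound to a saturated ring carbon; it shows that a swap at this position can move the read-out beyond the scatter.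

Compound 3 `COC(=O)NC[C@H]1CN(c2ccc(-n3cc(-c4ccccn4)cn3)c(F)c2)C(=O)O1` is not yet measured. It differs from compound 1 as (methoxycarbonyl)amino in place of 2,5-dioxopyrrolidin-1-yl on a saturated chain carbon bound to a saturated ring carbon. The chain grows shorter by a ring and gains a hydrogen-bond donor while keeping two acceptors. Going by the values given here, the step to compound 2 is the only guide and does not involve the same entering group, so its size is at best a rough pointer. On that basis compound 3 is expected to sit above compound 1 by a modest margin, with the step of a 2.0-fold higher number from compound 1 to compound 3 (0.30 log units; within the scatter) expected. The estimate for compound 3 is 90000 nM, expected to lie between 30000 nM and 270000 nM.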

Compound 3, solubility: 34100 nM
Estimate against measurement, compound 3: 2.6-fold (0.42 log units) above, within the range that was stated.
By their numbers in this assay, from the lowest: compounds 3 and 1 (each within the scatter of the next); then compound 2.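

With (methoxycarbonyl)amino in place of 2,5-dioxopyrrolidin-1-yl on a saturated chain carbon bound to a saturated ring carbon, this assay gives a 1.3-fold lower number from compound 1 to compound 3 (0.12 log units; within the scatter) and so does not separate the two compounds, although the entering group has no ring and carries 1 hydrogen-bond donor. Exchanging 1H-1,2,3-triazol-1-yl for the same group gives a 7.2-fold lower number from compound 2 to compound 3 (0.86 log units; beyond the scatter) and places compound 2 apart from both others, each of its steps being beyond the scatter. The earlier step could be read as showing that a swap at this position moves the read-out, but the three compounds now show that this does not hold for every swap: of the two groups compared with 2,5-dioxopyrrolidin-1-yl, only 1H-1,2,3-triazol-1-yl gives a step beyond the scatter. No measurement is available that explains these numbers.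

From the compounds shown here alone, it remains open whether an amine or a carboxylic acid at this place would read with compound 2 or with compounds 1 and 3. Going by these compounds, it is also open whether a longer chain carrying 1H-1,2,3-triazol-1-yl, or an imidazole in its place, would keep the number of compound 2.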